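Compound 2 to compound 3: isopropyl for pyrrolidin-1-yl

This account rests on a few compounds, and the source may have more. Where it says the series, first, only, none or still open, it means among the compounds named here.

In an ADME assay on NIH3T3 cells (Mus musculus) for cytotoxicity (a higher number here means that more compound is tolerated, a lower number that less compound is tolerated), the compounds gave
- compound 1 `CN1CCN(CC#Cc2cc3ncnc(Nc4ccc(OCc5cccc(F)c5)c(Cl)c4)c3s2)CC1` gives 4.8 uM
- compound 2 `Fc1cccc(COc2ccc(Nc3ncnc4cc(C#CCN5CCCC5)sc34)cc2Cl)c1` gives 6.4 uM

Among the compounds with values here, compound 2 stands within the scatter of its only measured neighbour. Compound 3 `CC(C)CC#Cc1cc2ncnc(Nc3ccc(OCc4cccc(F)c4)c(Cl)c3)c2s1` carries isopropyl in place of pyrrolidin-1-yl on a saturated chain carbon bound to a triple-bonded carbon. Within the data shown here, the one measured step (a 1.3-fold higher number from compound 1 to compound 2 (0.12 log units; within the scatter)) exchanged one ring for another, and no measured compound lacks such a ring, so it guides only loosely. No step beyond the scatter is therefore expected in this assay in either direction. The estimate means a small expected change (a 1.3-fold higher number from compound 2 to compound 3 (0.10 log units; within the scatter)). For compound 3 the expected value is 8 uM (estimated range 3 uM to 25 uM).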

Compound 3, half-maximal toxic concentration: > 50 uM
Compound 3 was reported as a limit (the forecaster's own chance of this, stated with the estimate: 15%); middle value at least 6.2-fold (0.79 log units) away from the limit.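

Exchanging a nitrogen-bearing ring for isopropyl on this saturated chain carbon changes the result in this assay, whereas exchanging one such ring for the other did not: an at least 7.8-fold higher number from compound 2 to compound 3 (0.89 log units; beyond the scatter), and an at least 10-fold higher number from compound 1 to compound 3 (1.01 log units; beyond the scatter). Compound 3 is reported only as a limit, so neither step has a known upper end: the limit of > 50 uM in this assay, at which 1 of the 3 values shown sits.

The compounds shown leave open whether the loss of the ring or of its nitrogen matters, a question that a cyclopentyl group and an open-chain dimethylamino group at this place would separate.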